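A few compounds are considered here, and "the series" means these few. Any claim that something is new, unique, unknown or untested is made for them only; others in the source may bear on it.

In a functional assay on SMMC-7721 cells (Homo sapiens) for antiproliferative activity, read by MTT assay, with a stated time of 48 h (a higher number here means a weaker inhibitor, a lower number a stronger inhibitor), compound 2 `CN1CCN(CCCn2nc(C3=C(c4cn(C)c5ccccc45)C(=O)NC3=O)c3cccnc32)CC1` gives > 100000 nM as its reading, which is a limit of the assay and not a number. Compound 1 `Cn1cc(C2=C(c3nn(CCCn4ccnc4)c4ncccc34)C(=O)NC2=O)c2ccccc21` likewise gives > 100000 nM as a limit and not a number. Going by the values given here, compound 3 `CN(C)CCCn1nc(C2=C(c3cn(C)c4ccccc34)C(=O)N(c3ccccc3)C2=O)c2cccnc21` reads 31200 nM and is the only compound here with a true number. The data therefore sit mostly at one edge, with the limit of > 100000 nM in this assay, at which 2 of the 3 values shown sit, as the main fact.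

Compound 4 `Cn1cc(C2=C(c3nn(CCCCn4ccnc4)c4ncccc34)C(=O)NC2=O)c2ccccc21` replaces the 3-(4-methylpiperazin-1-yl)propyl of compound 2 with a 4-(1H-imidazol-1-yl)butyl. In full, the change reads (1H-imidazol-1-yl)methyl in place of 4-methylpiperazin-1-yl on a saturated chain carbon, three bonds along the chain from an aromatic nitrogen and the rest of the structure stays the same. Among the compounds with values here, only one measured step bears on this, the exchange of the same two end groups on a propyl chain, and it reads a step that the two limits leave unreadable from compound 1 to compound 2 so it offers no size to carry over. The expectation therefore rests on compound 1, whose > 100000 nM is a limit. The step expected is a number no higher from compound 2 to compound 4 (the limit leaves the size open) and nothing beyond the scatter is expected, in either direction. Compound 4 is estimated at 100000 nM with a range from 30000 nM to 200000 nM and may well return only a limit.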

Compound 4, half-maximal inhibitory concentration: 29200 nM
Estimate against measurement, compound 4: 3.4-fold (0.53 log units) above; measured number outside the range, below it.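

In this assay, changing the end of this side chain, on a saturated chain carbon three bonds along the chain from an aromatic nitrogen, now gives a step that can be read, where the step between the two propyl compounds could not be: 4-(1H-imidazol-1-yl)butyl in place of 3-(4-methylpiperazin-1-yl)propyl gives an at least 3.4-fold lower number from compound 2 to compound 4 (0.53 log units; beyond the scatter). Keeping the imidazole end group and moving only from a propyl to a butyl chain gives an at least 3.4-fold lower number from compound 1 to compound 4 (0.53 log units; beyond the scatter), so with this end group the chain length alone changes the reading beyond the scatter. Both sizes are only the smallest the data allow, and the true steps may be larger, because each starts from a limit and not a number: the limit of > 100000 nM in this assay, at which 2 of the 4 values shown sit.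

Whether a butyl chain would also lower the number with 4-methylpiperazin-1-yl at its end remains open, since the compounds shown do not separate the end group from the chain length on that side. From the compounds shown here alone, it is also open whether a longer pentyl chain carrying the imidazole, or a morpholine at the end of the butyl chain, would move the number further in either direction.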